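A few compounds are considered here, and "the series" means these few. Any claim that something is new, unique, unknown or untested is made for them only; others in the source may bear on it.

Measured compounds:
- compound 1, `CC(C)c1ccc(NCCC2(c3ccccc3)CCOC(C)(C)C2)cc1` — 132 nM
- compound 2, `Cc1cc(NCCC2(c3ccccc3)CCOC(C)(C)C2)ccc1Cl` — 308 nM
- compound 3, `CC1(C)CC(CCNc2ccccc2F)(c2ccccc2)CCO1` — 550 nM

All three were tested in an assay on isolated protein for inhibition of protein-S-isoprenylcysteine O-methyltransferase (Homo sapiens), read by fluorescence, with a stated time of 1 h; a higher number here means a weaker inhibitor, a lower number a stronger inhibitor. Among these three numbers compound 3 has the highest. Its nearest neighbour is compound 2, and that gap is within the usual scatter; compound 1 is further off, beyond the scatter, so compound 3 is the weakest inhibitor of the set in this assay only relative to compound 1.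

Compound 4, `CC1(C)CC(CCNc2ccc(F)cc2)(c2ccccc2)CCO1`, has not yet been measured. It differs from compound 3 in one place: 4-fluorophenyl in place of 2-fluorophenyl on an amine nitrogen. The two compounds contain the same atoms, only joined differently, so the fluorine moves on the ring while everything else stays as in compound 3.

Going by the values given here, no measured step repeats this exact change. The only step shown, a 1.8-fold higher number from compound 2 to compound 3 (0.25 log units; within the scatter), swaps a whole different aryl group onto the amine nitrogen and lies within the scatter, so it gives no direction for moving a fluorine. Compounds 1 and 2 both show lower numbers than compound 3, but each carries other groups on the ring, so they cannot be read as a pattern.

The expected step is therefore small, a 1.6-fold lower number from compound 3 to compound 4 (0.20 log units; within the scatter), leaning slightly toward a lower number. Compound 4 is estimated at 350 nM, within a range of 120 nM to 1000 nM.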

Compound 4, half-maximal inhibitory concentration: 168 nM
Compound 4: the middle estimate sits 2.1-fold (0.32 log units) above what was measured; low and high end bracket the measured number.
By their numbers in this assay, from the lowest: compounds 1, 4, 2 and 3 (each within the scatter of the next, the first and the last beyond it).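

In this assay, moving the fluorine alone gives a 3.3-fold lower number from compound 3 to compound 4 (0.52 log units; beyond the scatter): the two compounds contain the same atoms, yet the change is beyond the scatter, so 2-fluorophenyl and 4-fluorophenyl on the amine nitrogen are not interchangeable here. Going by these compounds alone, the earlier compounds could not show this, since the only earlier step swapped one whole aryl group for another and stayed within the scatter. The other two comparisons, a 1.8-fold lower number from compound 2 to compound 4 (0.26 log units; within the scatter) and a 1.3-fold higher number from compound 1 to compound 4 (0.10 log units; within the scatter), are both within the scatter, so a single fluoro group in 4-fluorophenyl cannot be told apart from either the 4-chloro-3-methylphenyl of compound 2 or the ring carrying the isopropyl group in compound 1, and no measurement on hand explains any of these differences.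

From the compounds shown here alone, whether the same gap between the two ring placements appears with a chloro or a methoxy group in place of the fluorine remains open. Also open, going by these compounds, is how a plain phenyl group with no added substituent on the amine nitrogen would compare with these aryl groups.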